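A few compounds are considered here, and "the series" means these few. Any claim that something is new, unique, unknown or untested is made for them only; others in the source may bear on it.

Measured so far in an ADME assay on HCT-116 cells (Homo sapiens) for cytotoxicity, read by CellTiter-Glo, with a stated time of 72 h; on this read-out lower numbers stand for stronger inhibition and higher numbers for weaker inhibition:
compound 1 `CC1CCN(C2CCN(S(=O)(=O)c3cccnc3)CC2)CC1` gives > 10000 nM.
compound 2 `CC1CCN(C2CCN(S(=O)(=O)c3ccc(-c4ccccc4F)cc3)CC2)CC1` gives > 5000 nM.
compound 3 `CC1CCN(C2CCN(S(=O)(=O)c3cccnc3F)CC2)CC1` gives > 10000 nM.

Each of the three values is a limit of this assay, not a number. Two of them sit at the limit of > 10000 nM in this assay, at which 2 of the 3 values shown sit, and one at the limit of > 5000 nM in this assay, at which 1 of the 3 values shown sits. The change hydrogen in place of fluoro on an aromatic carbon gives a step that the two limits leave unreadable from compound 3 to compound 1. The difference between the core of compound 2 and the core of compound 3 is not broken down here.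

Compound 4 `CC1CCN(C2CCN(S(=O)(=O)c3ccc(-c4ccccc4)cc3)CC2)CC1` is not yet measured in this assay. It differs from compound 2 by hydrogen in place of fluoro on an aromatic carbon. This is the same kind of change as that from compound 3 to compound 1, not the same: there the place was on a six-membered aromatic ring with 1 nitrogen, next to the ring nitrogen, whereas here it is on a six-membered aromatic ring of carbon only, in both cases ortho to a large group.

Because compound 2 gives only > 5000 nM and the earlier step reads a step that the two limits leave unreadable from compound 3 to compound 1, the step is expected to be a step that the limit leaves unreadable from compound 2 to compound 4. Compound 4 is accordingly estimated at 10000 nM, with an expected range from 4000 nM to 30000 nM, most likely reported as a limit again.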

Compound 4, half-maximal inhibitory concentration: > 5000 nM
Compound 4 was reported as a limit; the forecaster's own chance of this, stated with the estimate: 85%; the middle value lies beyond the limit too.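

In this assay compound 4 gives > 5000 nM, which is a limit of the assay and not a number. Compound 2 is also reported as a limit, and no step can be read between compound 2 and compound 4. The compounds shown leave open whether 2-fluorophenyl and phenyl differ at all in this assay, and where any of the four compounds would give an actual number.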